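Adding a chloro group to the fluorophenyl anilide of compound 1

The source may report more compounds than this note shows. Statements on the series, on what has been measured and on what is new or still open speak of the compounds shown alone.

Compound 1 `Cc1nc(C(NC(=O)C(=O)Nc2ccc(F)cc2)C2CCCCN2)sc1CCO`: 109000 nM in an ADME assay on MT2 cells (Homo sapiens) for cytotoxicity, read by XTT assay, with a stated time of 4 days; a higher number here means that more compound is tolerated, a lower number that less compound is tolerated.
Compound 2 `CC(=O)N1CCCCC1C(NC(=O)C(=O)Nc1ccc(Cl)cc1)c1nc(C)c(CCO)s1`: > 84000 nM, a limit of this assay rather than a number.
Compound 3 `Cc1nc(C(NC(=O)C(=O)Nc2ccc(Cl)cc2)C2CCCN2)sc1CO`: 45000 nM.

Of the two compounds with a numbered value, compound 1 gives the highest number, and the gap down to compound 3 lies beyond the usual scatter. For the measured compounds named here, compound 2 is the one value sitting at the limit of > 84000 nM in this assay, at which 1 of the 3 values shown sits.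

Compound 4 `Cc1nc(C(NC(=O)C(=O)Nc2ccc(F)c(Cl)c2)C2CCCCN2)sc1CCO` differs from compound 1 in a single place: chloro in place of hydrogen on an aromatic carbon. Going by the values given here, no measured pair here shows what this change does. A modest downward step is expected, a 1.6-fold lower number from compound 1 to compound 4 (0.19 log units; within the scatter), small enough that it may not exceed the scatter. Compound 4 is therefore estimated at 70000 nM, with a range from 30000 nM to 150000 nM.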

Compound 4, half-maximal cytotoxic concentration: 94700 nM
For compound 4 the middle estimate is 1.4-fold (0.13 log units) below the measured one; the range from low to high includes it.
By their numbers in this assay, from the lowest: compound 3; then compounds 4 and 1 (each within the scatter of the next).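

In this assay, for the compounds shown here, chloro in place of hydrogen on the aromatic carbon ortho to the fluoro group gives a 1.2-fold lower number from compound 1 to compound 4 (0.06 log units; within the scatter), the first single-place comparison in this set. Going from 4-fluorophenyl to 3-chloro-4-fluorophenyl therefore leaves the read-out unchanged within the scatter, so this position takes a chlorine without a measurable shift in tolerated concentration. Nothing measured here explains why the step is so small.

The compounds shown leave open whether a methoxy group, a trifluoromethyl group or an amine on this same carbon would also stay within the scatter.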